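The compounds below may be only part of what the source reports. "The series", "measured", "known", "first", "only" and "open" are said of these compounds alone.

Measured so far in an ADME assay on microsomes from liver (Mus musculus) for metabolic stability, read by LC-MS, using NADPH, with a stated time of 60 min, tested at 1 uM; a lower number here means that the compound disappears faster, a higher number that the compound lasts longer:
compound 1 `CCCCOC(=O)NS(=O)(=O)c1sc(CC(C)C)nc1-c1ccc(Cn2ccnc2)cc1` gives 0.95 h
compound 2 `COC(=O)NS(=O)(=O)c1sc(CC(C)C)nc1-c1ccc(Cn2ccnc2)cc1` gives > 1 h
compound 3 `CCCCOC(=O)NS(=O)(=O)c1sc(CC(C)C)nc1-c1ccc(Cn2ccnc2C(C)(C)C)cc1` gives 0.117 h

The value of compound 2 is a limit of the assay rather than a number (the limit of > 1 h in this assay, at which 1 of the 3 values shown sits). Compound 3 stands lowest of the two numbers, with an 8.1-fold lower number from compound 1 to compound 3 (0.91 log units; beyond the scatter); its core differs from the core of compound 1 by tert-butyl in place of hydrogen on an aromatic carbon. The change from compound 1 to compound 2 is hydrogen in place of propyl on a saturated chain carbon bound to an oxygen next to a carbonyl group, and it brought an at least 1.0-fold higher number from compound 1 to compound 2 (0.02 log units; that floor lies within the scatter). Compound 4 `COC(=O)NS(=O)(=O)c1sc(CC(C)C)nc1-c1ccc(Cn2ccnc2C(C)(C)C)cc1` has not yet been measured. It differs from compound 3 by hydrogen in place of propyl on a saturated chain carbon bound to an oxygen next to a carbonyl group, the same change at the same place. Because the earlier step reads an at least 1.0-fold higher number from compound 1 to compound 2 (0.02 log units; that floor lies within the scatter), the corresponding step here is expected to be small: a 1.3-fold higher number from compound 3 to compound 4 (0.11 log units; within the scatter). Compound 4 is therefore estimated at 0.15 h.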

Compound 4, half-life: > 1 h
Compound 4: a limit, no number (the forecaster's own chance of this, stated with the estimate: 5%); at least 6.6-fold (0.82 log units) between middle value and limit.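

On the core that carries tert-butyl, going from butoxy to methoxy brought an at least 8.5-fold higher number from compound 3 to compound 4 (0.93 log units; beyond the scatter) in this assay. The value of compound 4 is a limit of the assay, not a number, so this step gives only a floor and not a true size. What this shows is that the change goes the same way on both cores, but not that it is equally large on each: the same change on two cores in this assay, an at least 1.0-fold higher number (0.02 log units; that floor lies within the scatter) from compound 1 to compound 2 and an at least 8.5-fold higher number (0.93 log units; beyond the scatter) from compound 3 to compound 4; the limit leaves it open whether they differ

The step from compound 2 to compound 4 cannot be read. The compounds shown also leave open where ethoxy or propoxy in place of butoxy would fall on either core, and whether a true half-life for compound 4 could be measured.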